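Methyl to Isopropyl Ester: Expected Effect on Agonist Potency

The source may report more compounds than this note shows. Statements on the series, on what has been measured and on what is new or still open speak of the compounds shown alone.

Of the compounds shown here, two have been measured in an assay on HEK-Blue hTLR2 cells for agonist activity at Toll-like receptor 2 (Homo sapiens), with a stated time of 24 h; a lower number here means that less compound is needed, a higher number that more compound is needed for the effect. Compound 1 `CCOC(=O)c1c(NC(=S)Nc2ccc(C(F)(F)F)cc2)sc2c1CCCC2` gives 11900 nM in this assay. Compound 2 `COC(=O)c1c(NC(=S)Nc2cccc3ccccc23)sc2c1CCC2` gives 3570 nM in this assay, the lowest of the two numbers; the number for compound 1 is higher by a margin beyond the usual scatter, but the two differ in more than one place, so no single change can be read from the gap.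

Compound 3 `CC(C)OC(=O)c1c(NC(=S)Nc2cccc3ccccc23)sc2c1CCC2` has not yet been measured. It differs from compound 2 by isopropyl in place of methyl on an oxygen next to a carbonyl group. Going by the values given here, no pair of measured compounds differs only at this oxygen, so there is no measured step of this kind to lean on; the ester variation between compound 1 and compound 2 is confounded by their other differences.

For compound 3 the expected step is a 1.3-fold higher number from compound 2 to compound 3 (0.10 log units; within the scatter), small and possibly within the scatter, with a slight lean toward a higher number. Compound 3 is therefore estimated at 4500 nM in this assay, with a range from 1500 nM to 14000 nM.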

Compound 3, half-maximal effective concentration: 180 nM
For compound 3 the middle estimate is 25-fold (1.40 log units) above the measured one; measured number outside the range, below it.
By their numbers in this assay, from the lowest: compound 3; then compound 2; then compound 1.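

In this assay, the group on the oxygen next to a carbonyl group proves to be a sensitive place: a 20-fold lower number from compound 2 to compound 3 (1.30 log units; beyond the scatter) with isopropyl in place of methyl. Going by these compounds alone, this is the first reading of a single change, which compound 1 and compound 2 could not give, as they differ in more than one place. The step is large and beyond the scatter, so the ester group cannot be treated as a neutral part of the shared core, at least for the structure of compound 2.

No measurement at hand accounts for the size of this step, so it stands as an observation only.

One step cannot show whether the number keeps falling as the group on this oxygen grows, or whether isopropyl is a peak; a tert-butyl ester, a cyclopentyl ester or a straight propyl chain would separate branching from size. Also open, on these data alone, are whether the same change carries over to the core of compound 1, and what a carboxylic acid or an amide in this place would give.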